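The source may hold more compounds than are shown below. What is called first, only, known or untested is meant among the compounds shown, and "the series" means these compounds.

Compounds measured so far:
- compound 2, `C[C@]1(c2ccc(O)cc2)CSc2cc(O)ccc2[C@H]1CCCCCCCCCC(CCCC(F)(F)C(F)(F)F)C(=O)O`: 81%
- compound 3, `C[C@]1(c2ccc(O)cc2)CSc2cc(O)ccc2[C@H]1CCCCCCCCCC(CCCC(F)(F)C(F)(F)C(F)(F)C(F)(F)F)C(=O)O`: 86%
- compound 1, `C[C@]1(c2ccc(O)cc2)CSc2cc(O)ccc2[C@H]1CCCCCCCCCNC(=O)NS(=O)(=O)CCCC(F)(F)C(F)(F)F`: "not determined" (no result reported)

All three share one core and differ only in the tail that hangs from it. In a functional assay on the whole organism for antagonist activity, with Mus musculus as the target, at a dose of 10 mg/kg by the oral route (on this read-out lower numbers stand for a weaker effect and higher numbers for a stronger effect at the one dose given), compound 2 gives 81%, and compound 3 gives 86%. Compound 2 holds the lower of the two numbers, but the step of a number 5 percentage points higher from compound 2 to compound 3 (within the scatter) is small, so the two are not told apart here. Compound 1 carries a different tail and has no result in this assay.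

Compound 4, `C[C@]1(c2ccc(O)cc2)CSc2cc(O)ccc2[C@H]1CCCCCCCCCC(CCCCC(F)(F)C(F)(F)F)C(=O)O`, changes the tail of compound 2 in one place: 2,2,3,3,3-pentafluoropropyl in place of 1,1,2,2,2-pentafluoroethyl on a saturated chain carbon, four bonds along the chain from a carbonyl carbon. Among the compounds with values here, the only measured step that bears on this, a number 5 percentage points higher from compound 2 to compound 3 (within the scatter), also lengthens the fluorinated tail and stays within the scatter. So no step beyond the scatter is expected in this assay. The step of a number 1 percentage points higher from compound 2 to compound 4 (within the scatter) is estimated as roughly flat. Compound 4 is therefore expected to give about 82%, with a likely range from 66% to 93%.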

Compound 4, a percentage reported as inhibition, in the whole organism at one dose (the size of the read-out at that dose, not a potency): 79%
Compound 4: middle estimate off by 3 percentage points, on the high side; measured number inside the range.
By their numbers in this assay, from the lowest: compounds 4, 2 and 3 (each within the scatter of the next).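

In this assay, placing 2,2,3,3,3-pentafluoropropyl in place of 1,1,2,2,2-pentafluoroethyl on a saturated chain carbon, four bonds along the chain from a carbonyl carbon, gives a number 2 percentage points lower from compound 2 to compound 4 (within the scatter). Compound 3 extends the fluorinated end of the tail, while compound 4 adds a carbon that bears no fluorine, and neither change moves the number beyond the scatter, as a number 5 percentage points higher from compound 2 to compound 3 (within the scatter) also shows. No measurement here offers an explanation for this flat result.

The compounds shown do not reveal whether this position would tolerate a tail with no fluorine at all, such as a plain hexyl chain, or one ending in an amine. As far as these compounds go, the tail of compound 1 also stays untested as a comparison, since compound 1 gives "not determined" (no result reported).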